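Propyl to butyl on the weak 2-methoxyphenyl ester

The source may report more compounds than this note shows. Statements on the series, on what has been measured and on what is new or still open speak of the compounds shown alone.

In a functional assay on M21 cells (Homo sapiens) for antiproliferative activity, read by sulforhodamine B assay, with a stated time of 48 h (on this read-out higher numbers stand for weaker inhibition and lower numbers for stronger inhibition), compound 1 (`COc1ccccc1OS(=O)(=O)c1ccc(N2CCN(C)C2=O)cc1`) gives 21000 nM and compound 3 (`CCCN1CCN(c2ccc(S(=O)(=O)Oc3ccc(OC)cc3)cc2)C1=O`) gives 23000 nM on the same scale. Compound 2 (`CCCN1CCN(c2ccc(S(=O)(=O)Oc3ccccc3OC)cc2)C1=O`) reads > 100000 nM as a limit of the assay and not a number. Compound 2 stands at the limit of > 100000 nM in this assay, at which 1 of the 3 values shown sits, and so has no exact place on the scale.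

Compound 4 (`CCCCN1CCN(c2ccc(S(=O)(=O)Oc3ccccc3OC)cc2)C1=O`) carries butyl where compound 2 carries propyl: methyl in place of hydrogen on a saturated chain carbon, three bonds along the chain from an amide-type nitrogen in a ring with methyl in place of hydrogen on a saturated chain carbon, three bonds along the chain from an amide-type nitrogen in a ring.

The measured step on the same chain is an at least 4.7-fold higher number from compound 1 to compound 2 (0.67 log units; beyond the scatter) with ethyl in place of hydrogen, and it goes towards weaker inhibition. The other measured step, an at least 4.3-fold lower number from compound 2 to compound 3 (0.63 log units; beyond the scatter) with 4-methoxyphenyl in place of 2-methoxyphenyl, leaves the chain untouched and bears on this change only by showing how the aryl group matters.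

With one chain step to go on and a limit as the starting point, weak inhibition is expected to persist. The expected outcome is a number no higher from compound 2 to compound 4 (the limit leaves the size open) with no step beyond the scatter foreseen. In this assay the value expected for compound 4 is 100000 nM with a range from 40000 nM to 200000 nM and a report as a bare limit is quite possible.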

Compound 4, half-maximal inhibitory concentration: > 100000 nM
Compound 4 gave a limit, no number (the forecaster's own chance of this, stated with the estimate: 60%); the middle value lies on the limit itself.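

Working notes on the chain. In this assay compound 4 gives > 100000 nM, which is a limit of the assay and not a number. Butyl in place of propyl therefore does not return the 2-methoxyphenyl ester to a measurable value, and the step between the two limits cannot be read. Against the methyl compound, propyl in place of hydrogen gives an at least 4.7-fold higher number from compound 1 to compound 4 (0.67 log units; beyond the scatter), so the butyl compound also lies beyond the scatter towards weaker inhibition, and propyl and butyl now both sit at the ceiling on this ester: the limit of > 100000 nM in this assay, at which 2 of the 4 values shown sit.

From the compounds shown here alone, whether butyl and propyl truly differ on this ester stays unknown, as does whether butyl would keep the measurable level of the 4-methoxyphenyl ester, where compound 3 gives 23000 nM in this assay. Also open, going by these compounds, is whether a hexyl chain, or an amine or a carboxylic acid in place of butyl, would bring the 2-methoxyphenyl ester back onto the scale.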